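Bromo series: extending the benzyl chain at the exocyclic amine

A few compounds are considered here, and "the series" means these few. Any claim that something is new, unique, unknown or untested is made for them only; others in the source may bear on it.

Measured so far:
- compound 1, `CCCn1cnc2c(N)nc(NCCCc3ccccc3)nc21`: 12600 nM
- compound 2, `CCCn1c(Br)nc2c(N)nc(NCc3ccccc3)nc21`: 650 nM

Both numbers come from an assay on CHO cells for displacement of a labelled ligand from transmembrane domain-containing protein TMIGD3 (Homo sapiens); on this read-out higher numbers stand for weaker inhibition and lower numbers for stronger inhibition. Compound 2 gives 650 nM in this assay, the lower of the two values; compound 1 gives 12600 nM, a higher number and a difference that is beyond the scatter. For the measured compounds named here, compound 1 and compound 2 differ in two places at once, so their values show only that compound 2 binds more strongly, not which of the two changes carries the difference.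

Compound 3, `CCCn1c(Br)nc2c(N)nc(NCCCc3ccccc3)nc21`, keeps the bromine-bearing core of compound 2 and differs from it in one place: phenethyl in place of phenyl on a saturated chain carbon bound to a nitrogen on an aromatic ring. Going by the values given here, no measured pair isolates this chain extension, so the size and direction of the step rest on the two values alone. Among the compounds with values here, compound 1, the only other compound with the longer chain, gives 12600 nM, which leans toward a weaker result for compound 3, though the bromine it lacks leaves that lean uncertain. A moderate step from compound 2 toward a higher number, a 3.8-fold higher number from compound 2 to compound 3 (0.59 log units; beyond the scatter), is expected. For compound 3 the estimate in this assay is 2500 nM, with a range from 600 nM to 10000 nM.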

Compound 3, inhibition constant: 1950 nM
Beside the measured number, compound 3's estimate is 1.3-fold (0.11 log units) above it, and the stated range covers the measured number.
By their numbers in this assay, from the lowest: compound 2; then compound 3; then compound 1.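

In this assay, the chain change can now be read alone on the bromine-bearing core: phenethyl in place of phenyl on a saturated chain carbon bound to a nitrogen on an aromatic ring gives a modest loss of binding (a 3.0-fold higher number from compound 2 to compound 3 (0.48 log units; beyond the scatter)). The bromine can also be read alone with the longer chain held constant, as bromo in place of hydrogen on an aromatic carbon gives a modest gain (a 6.5-fold lower number from compound 1 to compound 3 (0.81 log units; beyond the scatter)). Each of the two changes separating compound 1 from compound 2 therefore moves the number beyond the scatter on its own, and the two point the same way, though nothing on hand explains the size of either step.

Going by these compounds, the bromine step is read only with the phenethyl chain, so its size with the shorter phenyl-bearing chain remains open. Also open, on these data alone, is how the number would respond to chloro in place of bromo, to a longer chain at the same place, or to an amine or a carboxylic acid on the chain.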